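This account rests on a few compounds, and the source may have more. Where it says the series, first, only, none or still open, it means among the compounds named here.

Measured compounds:
- compound 1, `CCCCCCCCCCCCCC[C@H](OCOC)[C@H](CO)NC(=O)OC(C)(C)C`: 25.9%
- compound 2, `CCCCCCCCCCCCCC[C@H](OCOC)[C@H](CN(C(C)C)C(C)C)NC(=O)OC(C)(C)C`: 22.6%
- compound 3, `CCCCCCCCCCCCCC[C@H](OCOC)[C@H](CN(CCCC)CCCC)NC(=O)OC(C)(C)C`: 42.2%

In a functional assay on A549 cells (Homo sapiens) for antiproliferative activity, read by sulforhodamine B assay, with a stated time of 48 h, tested at 10 uM (on this read-out higher numbers stand for more inhibition at the one concentration tested (going by the name of the read-out) and lower numbers for less inhibition), compound 1 gives 25.9%, the second highest of the three numbers. Its nearest neighbour is compound 2, with a number 3.3 percentage points lower from compound 1 to compound 2 (within the scatter), while compound 3 lies furthest away, with a number 16.3 percentage points higher from compound 1 to compound 3 (beyond the scatter). Between compound 2 and compound 3 the step is a number 19.6 percentage points higher from compound 2 to compound 3 (beyond the scatter).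

The unmeasured compound 4, `CCCCCCCCCCCCCC[C@H](OCOC)[C@H](CN1CCN(C)CC1)NC(=O)OC(C)(C)C`, differs from compound 1 as follows: 4-methylpiperazin-1-yl in place of hydroxy on a saturated chain carbon, two bonds along the chain from an amide-type nitrogen. The two measured steps that bear on this are those that likewise replace the hydroxy group by a tertiary amine at the same place: the step to the diisopropylamino analogue, a number 3.3 percentage points lower from compound 1 to compound 2 (within the scatter), and the step to the dibutylamino analogue, a number 16.3 percentage points higher from compound 1 to compound 3 (beyond the scatter). One of these stayed within the scatter and the other gave a modest rise, so with a tertiary amine at this position the number has so far been level or higher. Within the data shown here, no measured compound carries a ring at this position, so the precedent is indirect.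

Compound 4 is therefore expected to lie near compound 1 or somewhat above it, with an estimated step of a number 5.1 percentage points higher from compound 1 to compound 4 (within the scatter) in this assay. The estimate for compound 4 is 31%, with an expected range from 16% to 48%.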

Compound 4, a percentage reported as inhibition, at one concentration (the size of the read-out at that concentration, not a potency): 18.3%
The estimate for compound 4 lay 12.7 percentage points above the measured number, within the range that was stated.
By their numbers in this assay, from the lowest: compounds 4, 2 and 1 (each within the scatter of the next); then compound 3.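

In this assay, a ring at this place, on a saturated chain carbon, two bonds along the chain from an amide-type nitrogen, gives a number within the scatter of the hydroxy compound (a number 7.6 percentage points lower from compound 1 to compound 4 (within the scatter)) and of the diisopropylamino compound (a number 4.3 percentage points lower from compound 2 to compound 4 (within the scatter)). The dibutylamino group of compound 3 now stands apart from both the ring and the diisopropylamino group, as 4-methylpiperazin-1-yl in its place gives a step beyond the scatter (a number 23.9 percentage points lower from compound 3 to compound 4 (beyond the scatter)), so replacing hydroxy with a tertiary amine does not in itself raise the number among these compounds, and compound 3 is the only one that departs from the other three. Nothing measured here bears on why the dibutylamino group differs from the other two amines.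

Whether the higher number follows the length of the open chains remains open, since the compounds shown include neither dipropylamino nor dihexylamino at this place. From the compounds shown here alone, it is equally open whether a ring without the second nitrogen, such as piperidin-1-yl, or a ring with an oxygen in its place, such as morpholin-4-yl, would stay with compound 4 or move toward compound 3.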